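The source may report more compounds than this note shows. Statements on the series, on what has been measured and on what is new or still open speak of the compounds shown alone.

Compounds measured in a functional assay on CHO cells for agonist activity at Free fatty acid receptor 1 (Homo sapiens), read by FLIPR; a lower number here means that less compound is needed, a higher number that more compound is needed for the effect:
- compound 2, `Cc1cccc(OCC(=O)Nc2ccc(OCC(=O)O)c(F)c2)c1`: 108 nM
- compound 3, `CC(Oc1cccc(C(C)(C)C)c1)C(=O)Nc1ccc(OCC(=O)O)c(F)c1`: 140 nM
- compound 1, `CCOc1ccccc1OC(C)C(=O)Nc1ccc(OCC(=O)O)c(F)c1`: "not determined" (no result reported)

All three compounds, and the unmeasured compound 4, `Cc1ccc(OC(C)C(=O)Nc2ccc(OCC(=O)O)c(F)c2)cc1C`, share the same core, an aryloxyacetic acid bearing a fluorine and an anilide linked through an ether to an aryl group. In this assay compound 2 gives 108 nM and compound 3 gives 140 nM; the two values lie within the usual scatter of each other, so nothing separates them. Going by the values given here, compound 1 stands without a number: in this assay compound 1 gives "not determined" (no result reported), so no position for it on the scale can be stated, and no step from it can be measured.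

The change from compound 1 to compound 4 is 3,4-dimethylphenyl in place of 2-ethoxyphenyl on an oxygen on a saturated carbon. Among the compounds with values here, no measured pair frames this change, so its size and direction cannot be taken from the data. Compound 4 is instead expected to sit in the region where compound 2 gives 108 nM and compound 3 gives 140 nM. Compound 4 is estimated at 110 nM, with an expected range from 30 nM to 400 nM, the width reflecting the absence of any measured step.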

Compound 4, half-maximal effective concentration: 133 nM
For compound 4 the middle estimate is 1.2-fold (0.08 log units) below the measured one, within the range that was stated.
By their numbers in this assay, from the lowest: compounds 2, 4 and 3 (each within the scatter of the next).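

Going by these compounds alone, compound 1 has no reported result, so no step to compound 4, at 133 nM, can be read. The compounds shown leave open how 3,4-dimethylphenyl in place of 2-ethoxyphenyl changes the value, in either size or direction. No supporting evidence bears on this result.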